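A few compounds are considered here, and "the series" means these few. Any claim that something is new, unique, unknown or untested is made for them only; others in the source may bear on it.

Compound 1 `[N-]=[N+]=NC[C@H]1O[C@H](CO)[C@@H](O)[C@H](O)[C@H]1O` is the weakest inhibitor of the three measured compounds: in an assay on isolated protein (Oryctolagus cuniculus) for inhibition of glycogen phosphorylase, brain form (Homo sapiens) (on this read-out higher numbers stand for weaker inhibition and lower numbers for stronger inhibition), compound 1 gives 22400000 nM, the highest number of the set. Compound 2 `CNNC(=O)[C@H]1O[C@H](CO)[C@@H](O)[C@H](O)[C@H]1O` gives 1800000 nM in this assay, and compound 3 `NCCC1OC(CO)C(O)C(O)C1O` gives 4500000 nM. Among the measured compounds shown here, the only single-point step among the measured compounds, a 12-fold lower number from compound 1 to compound 2 (1.09 log units; beyond the scatter), exchanges one substituent for another on the shared core. Compound 4 `[N-]=[N+]=NC[C@@H]1O[C@H](CO)[C@@H](O)[C@H](O)[C@H]1O` differs from compound 1 in a different way: the two compounds have the same atoms and bonds; at least one stereo element is drawn with a configuration in one of them and without one in the other: 1 of 6 stereo elements differ; a stereocentre at a saturated ring carbon is drawn R in compound 1 and S in compound 4. For the measured compounds named here, no measured pair differs by such an inversion alone, so the step from compound 1 to compound 2 does not bear on it, and the values of compound 3 give no guidance either. Going by the values given here, with no comparable step to lean on, the outcome is open: the change could move the number in either direction or leave it within the scatter. Compound 4 is therefore expected to sit close to its parent, the estimated step being a 1.1-fold lower number from compound 1 to compound 4 (0.05 log units; within the scatter). Compound 4 is expected to show an inhibition constant of about 20000000 nM, with a range from 4000000 nM to 100000000 nM.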

Compound 4, inhibition constant: 15200000 nM
Estimate against measurement, compound 4: 1.3-fold (0.12 log units) above, within the range that was stated.
By their numbers in this assay, from the lowest: compound 2; then compound 3; then compounds 4 and 1 (each within the scatter of the next).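

In this assay, the inversion of the stereocentre at a saturated ring carbon amounts to a 1.5-fold lower number from compound 1 to compound 4 (0.17 log units; within the scatter), so with azidomethyl as the substituent the configuration drawn at this carbon does not separate the two compounds. The earlier compounds could not show this, as their only single-point step exchanged the substituent, and that exchange, a 12-fold lower number from compound 1 to compound 2 (1.09 log units; beyond the scatter), remains the one change shown here to move the number beyond the scatter. One caution applies to reading the pair as a clean inversion: the fact that one of compounds 1 and 4 is drawn with a defined configuration and the other without, at the place where they differ

The compounds shown leave open whether the configuration at this carbon would matter with the (methylamino)carbamoyl group of compound 2 in place of azidomethyl. The same question stands for other groups at this carbon, such as a primary amine, a carboxylic acid or a longer chain.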